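Expected effect of adding one methoxy to compound 3

This account rests on a few compounds, and the source may have more. Where it says the series, first, only, none or still open, it means among the compounds named here.

Measured in an ADME assay on BHK-21 cells (Mesocricetus auratus) for cytotoxicity, read by MTT assay (a higher number here means that more compound is tolerated, a lower number that less compound is tolerated), so far:
Compound 1 `COc1ccc(-c2nc3cc(C(C)=O)ccc3[nH]2)c(OC)c1` gives 50000 nM
Compound 2 `COc1ccc(-c2nc3cc(/C(C)=N/O)ccc3[nH]2)c(OC)c1` gives > 100000 nM (a limit of the assay, not a number)
Compound 3 `COc1ccc(-c2nc3cc(/C(C)=N/NC(N)=S)ccc3[nH]2)cc1` gives 13000 nM

Of the two actual numbers, compound 3 has the lower (13000 nM) and compound 1 the higher (50000 nM). Compared with compound 3, compound 4 `COc1ccc(-c2nc3cc(/C(C)=N/NC(N)=S)ccc3[nH]2)c(OC)c1` carries methoxy in place of hydrogen on an aromatic carbon (ortho to a large group and meta to a methoxy group). Among the compounds with values here, no measured step tests this swap. The only one (an at least 2.0-fold higher number from compound 1 to compound 2 (0.30 log units; that floor lies within the scatter)) changes a different group and rests on the limit of > 100000 nM in this assay, at which 1 of the 3 values shown sits, so it offers no size to carry over. No step beyond the scatter is therefore expected in this assay. The expected step is a 1.4-fold higher number from compound 3 to compound 4 (0.14 log units; within the scatter) (an estimate). The estimate for compound 4 is 18000 nM (expected range 6000 nM to 55000 nM).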

Compound 4, half-maximal cytotoxic concentration: 28000 nM
For compound 4 the middle estimate is 1.6-fold (0.19 log units) below the measured one; the measured number falls inside the stated range.
By their numbers in this assay, from the lowest: compound 3; then compounds 4 and 1 (each within the scatter of the next). At a limit, above all of these: compound 2.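

In this assay, within the data shown here, methoxy in place of hydrogen on this aromatic carbon, ortho to a large group, gives a 2.2-fold higher number from compound 3 to compound 4 (0.33 log units; beyond the scatter), the first measured step for this swap. Replacing the larger group on the aromatic carbon gives a 1.8-fold lower number from compound 1 to compound 4 (0.25 log units; within the scatter), so that change separates compound 1 and compound 4 by no more than the usual scatter. Changing the group on the double-bonded nitrogen gives an at least 3.5-fold lower number from compound 2 to compound 4 (0.55 log units; beyond the scatter), but this is only a floor: the limit of > 100000 nM in this assay, at which 1 of the 4 values shown sits.

As far as these compounds go, whether a hydroxyl or an amine in place of this methoxy would give a similar number remains open. Among these compounds, with only one pair testing the swap, it is also unknown whether methoxy has the same effect when other groups are on the core.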